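Oral exposure of an adamantane trioxolane with a new amine tail

A few compounds are considered here, and "the series" means these few. Any claim that something is new, unique, unknown or untested is made for them only; others in the source may bear on it.

In an ADME assay on the whole organism (strain FVB) for pharmacokinetics, with Mus musculus as the target, read by LC-MS, at a dose of 30 mg/kg by the oral route (on this read-out higher numbers stand for higher exposure at the dose given and lower numbers for lower exposure), compound 1 `CC(C)(O)CN1CCC(Oc2ccc([C@H]3CC[C@]4(CC3)OOC3(O4)C4CC5CC(C4)CC3C5)cc2)CC1` gives 14200 ng.h/mL. Its neighbours differ only at the group on the oxygen on the aromatic ring: compound 2 `c1cc([C@H]2CC[C@]3(CC2)OOC2(O3)C3CC4CC(C3)CC2C4)ccc1OC1CCNCC1` gives 7200 ng.h/mL and compound 3 `CC1(C)CC(O)(COc2ccc([C@H]3CC[C@]4(CC3)OOC3(O4)C4CC5CC(C4)CC3C5)cc2)CC(C)(C)N1` gives 17300 ng.h/mL. Compound 1 sits between them, and both of its steps stay within the scatter: a 2.0-fold lower number from compound 1 to compound 2 (0.29 log units; within the scatter) and a 1.2-fold higher number from compound 1 to compound 3 (0.09 log units; within the scatter). Within the data shown here, only the step that skips compound 1 reaches beyond it, a 2.4-fold higher number from compound 2 to compound 3 (0.38 log units; beyond the scatter).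

Compound 4 `O[C@H]1CC[C@H](NCCCOc2ccc([C@H]3CC[C@]4(CC3)OOC3(O4)C4CC5CC(C4)CC3C5)cc2)CC1` carries a different change at the same place: 3-((4-hydroxycyclohexyl)amino)propyl in place of 1-(2-hydroxy-2-methylpropyl)piperidin-4-yl on an oxygen on an aromatic ring. Among the measured compounds shown here, none of the three measured steps removes the ring amine and puts an open chain with a hydroxycyclohexyl in its place, so no step maps this change directly. What the measured steps show is that two distinct replacements of this group, from compound 1 to compound 2 and from compound 1 to compound 3, moved exposure by amounts within the scatter. On that basis the expected step for compound 4 is a 1.4-fold lower number from compound 1 to compound 4 (0.15 log units; within the scatter), with the estimate for compound 4 in this assay put at 10000 ng.h/mL, ranging from 4000 ng.h/mL to 25000 ng.h/mL.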

Compound 4, area under the concentration-time curve: 6570 ng.h/mL
The estimate for compound 4 lay 1.5-fold (0.18 log units) above the measured number, within the range that was stated.
By their numbers in this assay, from the lowest: compounds 4, 2, 1 and 3 (each within the scatter of the next, the first and the last beyond it).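

In this assay, the open chain 3-((4-hydroxycyclohexyl)amino)propyl is the first change shown at this oxygen on the aromatic ring to move the number beyond the scatter from the 1-(2-hydroxy-2-methylpropyl)piperidin-4-yl group (a 2.2-fold lower number from compound 1 to compound 4 (0.33 log units; beyond the scatter)). The position therefore does not tolerate every replacement equally, as the gap to the (4-hydroxy-2,2,6,6-tetramethylpiperidin-4-yl)methyl group is also beyond the scatter (a 2.6-fold lower number from compound 3 to compound 4 (0.42 log units; beyond the scatter)), yet losing the ring amine is not enough by itself to set the open chain apart, since it cannot be told from the plain piperidin-4-yl group (a 1.1-fold lower number from compound 2 to compound 4 (0.04 log units; within the scatter)). Nothing given here explains these differences in exposure.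

The compounds shown leave open whether the hydroxycyclohexyl or the open chain accounts for the step from compound 1. A 3-aminopropyl or 3-(morpholin-4-yl)propyl group at this oxygen would help to separate the two.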